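This account rests on a few compounds, and the source may have more. Where it says the series, first, only, none or still open, it means among the compounds named here.

Measured so far:
- Compound 1, `COC(=O)C1=C(C)N=C(C)/C(=C(\O)OC)C1c1ccccc1Cl`: 2.19 nM
- Compound 2, `COC(=O)C1=C(C)N=C(C)/C(=C(\O)OC)C1c1c(F)c(F)c(F)c(F)c1F`: 4.37 nM

Both numbers come from a functional assay (muscle tissue) with Cavia porcellus as the target; a higher number here means that more compound is needed for the effect, a lower number that less compound is needed. Compound 1 has the lowest of the two numbers, and compound 2 sits within the usual scatter of it, so the two cannot be told apart. Compound 3, `COC(=O)C1=C(C)N=C(C)/C(=C(\O)OC)C1c1ccc(I)cc1`, has not been measured. It differs from compound 1 in one place: 4-iodophenyl in place of 2-chlorophenyl on a saturated ring carbon. Among the compounds with values here, no measured pair shows this change, so its effect is open. The expected step in this assay, a 14-fold higher number from compound 1 to compound 3 (1.14 log units; beyond the scatter), is toward a higher number, beyond the scatter. For compound 3 the estimate is 30 nM, in the range 6 nM to 150 nM.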

Compound 3, half-maximal effective concentration: 22900 nM
The estimate for compound 3 lay 760-fold (2.88 log units) below the measured number; measured number above the stated range.
By their numbers in this assay, from the lowest: compounds 1 and 2 (each within the scatter of the next); then compound 3.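

The change to 4-iodophenyl on this saturated ring carbon gives, in this assay, a 10000-fold higher number from compound 1 to compound 3 (4.02 log units; beyond the scatter), so the substituted phenyl at this position strongly affects the number. The two groups match in heavy-atom count and have no hydrogen-bond donors or acceptors, so these counts do not separate them. No measured evidence here accounts for the step.

The swap changes both the halogen and its place on the phenyl ring, and these two changes cannot be separated. Values for 4-chlorophenyl and 2-iodophenyl at this position would show which of them carries the step.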